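Compound 3 to compound 4: hydrogen in place of methyl

The source may hold more compounds than are shown below. What is called first, only, known or untested is meant among the compounds shown, and "the series" means these compounds.

In a physicochemical assay for lipophilicity, measured as octanol-water partition, at pH 7.4 (a higher number here means a more lipophilic compound, a lower number a more polar compound), compound 1 (`Cc1ccc2[nH]c(C(=O)N[C@H]3CN(S(=O)(=O)C4CCOCC4)C[C@@H]3C(=O)NCCN(C)C)cc2c1`) gives 1 and compound 2 (`Cc1ccc2[nH]c(C(=O)N[C@H]3CN(S(=O)(=O)c4ccccc4)CC[C@H]3C(=O)NCCN(C)C)cc2c1`) gives 1.9 while compound 3 (`Cc1ccc2[nH]c(C(=O)N[C@H]3CCN(S(=O)(=O)c4ccccc4Cl)C[C@@H]3C(=O)N[C@H]3CCCN(C)C3)cc2c1`) stands highest of the three at 3.1 with both gaps beyond the scatter. No two of these compounds differ in one place only, so the series offers no measured step for the change now in question. The gaps between compound 3 and the other two cannot be assigned to any single group.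

Compound 4 (`Cc1ccc2[nH]c(C(=O)N[C@H]3CCN(S(=O)(=O)c4ccccc4Cl)C[C@@H]3C(=O)N[C@H]3CCCNC3)cc2c1`) departs from compound 3 in one place. The change reads hydrogen in place of methyl on an amine nitrogen in a ring and amounts to hydrogen in place of methyl on an amine nitrogen in a ring, two ring bonds from the ring atom that bears a large group. In other words, 1-methylpiperidin-3-yl becomes piperidin-3-yl.

For the measured compounds named here, with no measured precedent, the expectation in this assay rests on the structural change alone. A small fall is expected, estimated as a number 0.50 log units lower from compound 3 to compound 4 (beyond the scatter) and so probably only just beyond the scatter. The estimate for compound 4 is 2.6 (expected range from 2.1 to 3).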

Compound 4, distribution coefficient: 1.9
For compound 4 the middle estimate is 0.70 log units above the measured one, outside the stated range (below it).
By their numbers in this assay, from the lowest: compound 1; then compounds 2 and 4 (each within the scatter of the next); then compound 3.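

In this assay, for the compounds shown here, hydrogen in place of methyl on an amine nitrogen in a ring gives a number 1.20 log units lower from compound 3 to compound 4 (beyond the scatter), and this is the first one-place comparison. Going by these compounds alone, compounds 1 to 3 offered no such pair, so their gaps could not be assigned to any single group; this step can be assigned to one change, 1-methylpiperidin-3-yl to piperidin-3-yl. It shows that, with the rest of compound 3 held constant, the loss of a methyl group of a single carbon at this position is enough to move the read-out beyond the scatter, although no measurement to hand bears on why the step has this size.

Within the data shown here, the series rests on this single pair, so it remains open whether the step keeps its size with a different group on the sulfonyl or on a different amide side chain, such as the one carried by compound 1 and compound 2. On these data alone, it also remains open how an ethyl group, an acetyl group or a cyclopropyl group on the same ring nitrogen would compare with hydrogen and methyl.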